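Series notes: anilino to diethylamino at the nitrile-bearing ring

The source may hold more compounds than are shown below. What is called first, only, known or untested is meant among the compounds shown, and "the series" means these compounds.

Measured so far:
compound 1, `N#Cc1c(F)c(Cl)c2nc(N)nc(N)c2c1F`: 0.14 ug/mL
compound 2, `N#Cc1c(Nc2ccccc2)c(Cl)c2nc(N)nc(N)c2c1F`: 3.7 ug/mL

Going by the values given here, in a functional assay on SK-OV-3 cells (Homo sapiens) for cytotoxicity, read by MTT assay (a lower number here means a stronger inhibitor, a higher number a weaker inhibitor), compound 2 gives 3.7 ug/mL, the highest of the two numbers so far; its nearest neighbour is compound 1, which gives 0.14 ug/mL. Among the compounds with values here, the single step between measured compounds is a 26-fold higher number from compound 1 to compound 2 (1.42 log units; beyond the scatter), a large move toward weaker inhibition.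

Compound 3, `CCN(CC)c1c(C#N)c(F)c2c(N)nc(N)nc2c1Cl`, is not yet measured. Against compound 2 the change is diethylamino in place of anilino on an aromatic carbon. Within the data shown here, the one step on record exchanges fluoro for anilino; no measured step exchanges one nitrogen-linked substituent for another at this place, so the bearing of that step on compound 3 is indirect. An amine remains on the aromatic carbon in both compound 2 and compound 3, which speaks for a number nearer compound 2 than compound 1. The expected step is therefore small, a 1.9-fold lower number from compound 2 to compound 3 (0.27 log units; within the scatter), not clearly beyond the scatter in either direction, with the larger uncertainty on the side of compound 1.

For compound 3 in this assay the estimate is 2 ug/mL, expected range 0.5 ug/mL to 8 ug/mL.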

Compound 3, half-maximal inhibitory concentration: 0.4 ug/mL
The estimate for compound 3 lay 5.0-fold (0.70 log units) above the measured number; measured number outside the range, below it.
By their numbers in this assay, from the lowest: compound 1; then compound 3; then compound 2.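

In this assay, the position ortho to a chloro group and ortho to a cyano group proves sensitive to which amine it carries, not only to whether it carries one: a 9.3-fold lower number from compound 2 to compound 3 (0.97 log units; beyond the scatter) is the change seen on going from anilino to diethylamino. A nitrogen link at this carbon therefore does not by itself set the number, and the open diethylamino chain stands apart from the ring-bearing anilino group. Fluoro still gives the lowest number of the three, with a 2.9-fold higher number from compound 1 to compound 3 (0.46 log units; beyond the scatter) on replacing it by diethylamino, and no measurement on hand accounts for the order of these groups.

Anilino and diethylamino differ at once in the aromatic ring and in the hydrogen-bond donor, and the series shown does not separate the two: cyclohexylamino would keep the donor without the aromatic ring, while N-methylanilino would keep the ring without the donor. Also open, as far as these compounds go, is whether a smaller amine, such as dimethylamino or a plain amino group, would bring the number closer to that of compound 1.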